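This account rests on a few compounds, and the source may have more. Where it says the series, first, only, none or still open, it means among the compounds named here.

In a functional assay on HEL cells (Homo sapiens) for cytotoxicity, read by microscopy (on this read-out higher numbers stand for lower toxicity in this test and lower numbers for higher toxicity in this test), compound 2 (`Cc1cn([C@@H]2O[C@H](CO[Si](C)(C)C(C)(C)C)[C@@]3(OS(=O)(=O)C=C3NCCC(N)=O)[C@H]2O[Si](C)(C)C(C)(C)C)c(=O)n(C)c1=O`) is reported only as a limit, >= 80000 nM. Compound 1 (`Cc1cn([C@@H]2O[C@H](CO[Si](C)(C)C(C)(C)C)[C@@]3(OS(=O)(=O)C=C3NC(=O)c3ccccc3)[C@H]2O[Si](C)(C)C(C)(C)C)c(=O)n(C)c1=O`) also stands at a limit in this assay, >= 3200 nM. Compound 3 (`Cc1cn([C@@H]2O[C@@H]3COC(=O)[C@]3(OS(C)(=O)=O)[C@H]2O)c(=O)[nH]c1=O`) likewise gives only a limit in this assay, >= 400000 nM. Among the measured compounds shown here, the single step between measured compounds that differ in one place, a step that the two limits leave unreadable from compound 1 to compound 2, has no readable size; both of its ends are limits, the limit of >= 3200 nM in this assay, at which 1 of the 3 values shown sits, and (the limit of >= 80000 nM in this assay, at which 1 of the 3 values shown sits). Compound 2 therefore cannot be placed against the other two values shown beyond the statement that it, too, sits at a limit.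

Compound 4 (`COC(=O)CNC1=CS(=O)(=O)O[C@@]12[C@@H](CO[Si](C)(C)C(C)(C)C)O[C@@H](n1cc(C)c(=O)n(C)c1=O)[C@@H]2O[Si](C)(C)C(C)(C)C`) differs from compound 2 by methoxycarbonyl in place of carbamoylmethyl on a saturated chain carbon bound to an amine nitrogen. For the measured compounds named here, no measured step bears on this change: the only step recorded joins two limits and cannot be sized, and the third value shown, (the limit of >= 400000 nM in this assay, at which 1 of the 3 values shown sits), is a limit as well. With nothing in the data that points in either direction, compound 4 is expected to move from compound 2 by a number no higher from compound 2 to compound 4 (the limit leaves the size open), a step not beyond the scatter. Compound 4 is thus estimated to give 80000 nM in this assay, within a range from 20000 nM to 400000 nM, with a further limit rather than a number the likeliest report.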

Compound 4, minimum cytotoxic concentration: >= 400000 nM
Compound 4: only a limit was reported (the forecaster's own chance of this, stated with the estimate: 80%); at least 5.0-fold (0.69 log units) between middle value and limit.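

In this assay compound 4 gives >= 400000 nM, which is a limit and not a number. Compound 1 and compound 2 also stand at limits, and the steps from each of them to compound 4 cannot be read. The compounds shown leave open whether changing the group on the amine nitrogen shifts this read-out at all.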